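From difluorophenyl to methoxyphenyl on the shared core

This account rests on a few compounds, and the source may have more. Where it says the series, first, only, none or still open, it means among the compounds named here.

In an ADME assay on MRC5 cells (Homo sapiens) for cytotoxicity, read by fluorescence and resazurin assay, with a stated time of 3 days (a higher number here means a weaker inhibitor, a lower number a stronger inhibitor), compound 3 (`Cc1cn(C2CCN(Cc3cccc(Oc4ccc(F)c(F)c4)c3)CC2)c(=O)[nH]c1=O`) gives > 64000 nM as a limit of the assay, not a number. Compound 2 (`Cc1cccc(Oc2cccc(CN3CCC(n4cc(C)c(=O)[nH]c4=O)CC3)c2)c1`) gives > 64000 nM in this assay as a limit too. Only compound 1 (`Cc1cn(C2CCN(Cc3cccc(Oc4ccc(Cl)cc4)c3)CC2)c(=O)[nH]c1=O`), with 4-chlorophenyl, gives 25100 nM as a true number.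

Compound 4 (`COc1ccc(Oc2cccc(CN3CCC(n4cc(C)c(=O)[nH]c4=O)CC3)c2)cc1`) carries 4-methoxyphenyl in place of 3,4-difluorophenyl on an oxygen on an aromatic ring. Two measured steps at this place lead away from 4-chlorophenyl: an at least 2.5-fold higher number from compound 1 to compound 2 (0.40 log units; beyond the scatter) and an at least 2.5-fold higher number from compound 1 to compound 3 (0.40 log units; beyond the scatter) with each at least modest and beyond the scatter. The third, a step that the two limits leave unreadable from compound 2 to compound 3 with its size unknown, adds nothing.

None of these steps gives a size for the new group, so only a small move toward a lower number is expected, if any. The expected change is an at least 1.4-fold lower number from compound 3 to compound 4 (0.15 log units; that floor lies within the scatter) in this estimate. Compound 4 is expected at 45000 nM in this assay with an estimated range from 18000 nM to 90000 nM for that reading.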

Compound 4, half-maximal inhibitory concentration: 28000 nM
The estimate for compound 4 lay 1.6-fold (0.21 log units) above the measured number; the measured number falls inside the stated range.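

In this assay, the place on the oxygen now holds a second group that gives a true number and not a limit, so 4-chlorophenyl no longer stands alone in that respect. The change to methoxy is a 1.1-fold higher number from compound 1 to compound 4 (0.05 log units; within the scatter), so 4-chlorophenyl and 4-methoxyphenyl cannot be told apart here. Against the other two groups the result is an at least 2.2-fold lower number from compound 3 to compound 4 (0.35 log units; beyond the scatter) and an at least 2.2-fold lower number from compound 2 to compound 4 (0.35 log units; beyond the scatter), and both sizes are only floors because compound 2 and compound 3 each stop at a limit: the limit of > 64000 nM in this assay, at which 2 of the 4 values shown sit.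

Going by these compounds, how far compound 2 and compound 3 lie past that limit stays open, so the full size of these steps is unknown. Also open, on these data alone, is whether an amine or a carboxylic acid on this ring would give a true number in this assay.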